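This account rests on a few compounds, and the source may have more. Where it says the series, first, only, none or still open, it means among the compounds named here.

Compound 1 `CC(C)S(=O)(=O)N1CCN(S(=O)(=O)CCCN2CCC(CNC(=O)c3cccc4c3OCCO4)CC2)CC1` gives 0.126 nM in an assay on isolated protein for inhibition of 5-hydroxytryptamine receptor 4 (Homo sapiens); on this read-out lower numbers stand for stronger inhibition and higher numbers for weaker inhibition. Compound 2 `CCCS(=O)(=O)N1CCN(S(=O)(=O)CCCN2CCC(CNC(=O)c3cccc4c3OCCO4)CC2)CC1` gives 0.1 nM. Compound 3 `CC(=O)N1CCN(S(=O)(=O)CCCN2CCC(CNC(=O)c3cccc4c3OCCO4)CC2)CC1` gives 0.126 nM.

Compound 3 stands level with compound 1 at the digits shown, and together they hold the highest of the three numbers; from compound 2 the step is a 1.3-fold higher number from compound 2 to compound 3 (0.10 log units; within the scatter). Compound 4 `CCCC1CCN(S(=O)(=O)CCCN2CCC(CNC(=O)c3cccc4c3OCCO4)CC2)CC1` differs from compound 3 by 4-propylpiperidin-1-yl in place of 4-acetylpiperazin-1-yl on a sulfonyl sulfur. The measured steps at this end of the molecule, a 1.3-fold lower number from compound 1 to compound 2 (0.10 log units; within the scatter) and no change at the digits printed from compound 1 to compound 3 (within the scatter), both sit within the scatter, yet none of them alters the ring itself or takes away its hydrogen-bond acceptor, so they bear on the change only in part. The expected step in this assay is therefore a 1.6-fold higher number from compound 3 to compound 4 (0.20 log units; within the scatter), small and uncertain in direction. For compound 4 the estimate is 0.2 nM, with a range from 0.06 nM to 0.7 nM.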

Compound 4, inhibition constant: 0.0631 nM
The estimate for compound 4 lay 3.2-fold (0.50 log units) above the measured number; the measured number falls inside the stated range.
By their numbers in this assay, from the lowest: compounds 4, 2, 1 and 3 (each within the scatter of the next).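

In this assay, 4-propylpiperidin-1-yl in place of 4-acetylpiperazin-1-yl on the sulfonyl sulfur gives a 2.0-fold lower number from compound 3 to compound 4 (0.30 log units; within the scatter), and the same comparison with the two sulfonylated piperazines gives a 1.6-fold lower number from compound 2 to compound 4 (0.20 log units; within the scatter) and a 2.0-fold lower number from compound 1 to compound 4 (0.30 log units; within the scatter). All three steps stay within the scatter, so at this position, among these compounds, a ring with 1 hetero atom and 0 hydrogen-bond acceptors matches the piperazine groups. On these data alone, whether an amine or a carboxylic acid on this ring, or a chain longer than propyl, would also match remains open. No measurement shown gives a reason for these steps.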